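Methyl for Trifluoromethyl on a Thienopyridine Amide Series

This account rests on a few compounds, and the source may have more. Where it says the series, first, only, none or still open, it means among the compounds named here.

Of the compounds shown here, three of one shared core have been measured in a functional assay on MKN-74 cells (Homo sapiens) for antiproliferative activity, with a stated time of 24 h; on this read-out higher numbers stand for weaker inhibition and lower numbers for stronger inhibition. Compound 1 `NC(=O)c1c(NC(=O)c2ccc(C(F)(F)F)cc2)sc2c1CCN(C(=O)Nc1ccccc1Cl)C2` gives 43900 nM. Compound 2 `Cc1ccc(C(=O)Nc2sc3c(c2C(N)=O)CCN(C(=O)Nc2ccccc2Cl)C3)cc1` gives 27600 nM, and the change between them, (methyl in place of trifluoromethyl on an aromatic carbon), made a step of a 1.6-fold lower number from compound 1 to compound 2 (0.20 log units; within the scatter). Compound 3 `NC(=O)c1c(NC(=O)c2ccccc2C(F)(F)F)sc2c1CCN(C(=S)Nc1ccccc1Br)C2` gives 23900 nM; the difference between the core of compound 1 and that of compound 3 is not broken down here. Compound 4 `Cc1ccccc1C(=O)Nc1sc2c(c1C(N)=O)CCN(C(=S)Nc1ccccc1Br)C2` has not been measured; it differs from compound 3 by methyl in place of trifluoromethyl on an aromatic carbon. This is the same kind of change as from compound 1 to compound 2, but the place differs: there it sat para to a large group, here ortho to a large group. Because the earlier step was a 1.6-fold lower number from compound 1 to compound 2 (0.20 log units; within the scatter), a step of similar size is expected, a 1.4-fold lower number from compound 3 to compound 4 (0.15 log units; within the scatter). Compound 4 is therefore estimated at 17000 nM, between 6000 nM and 50000 nM.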

Compound 4, half-maximal inhibitory concentration: > 50000 nM
Compound 4: no number, only a limit (the forecaster's own chance of this, stated with the estimate: 15%); middle value at least 2.9-fold (0.46 log units) from the limit.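

In this assay compound 4 reads > 50000 nM, which is a limit of the assay and not a number: the limit of > 50000 nM in this assay, at which 1 of the 4 values shown sits. On the core of compound 3, the change from trifluoromethyl to methyl gave an at least 2.0-fold higher number from compound 3 to compound 4 (0.32 log units; beyond the scatter), so the step seen on the core of compound 1 did not carry over: the same change on two cores in this assay, a 1.6-fold lower number (0.20 log units; within the scatter) from compound 1 to compound 2 and an at least 2.0-fold higher number (0.32 log units; beyond the scatter) from compound 3 to compound 4, at least 3.3-fold (0.52 log units) apart, beyond the scatter of two such steps. As far as these compounds go, the full size of the new step remains unknown, and the two steps differ in both the core and the place of the group, so these compounds cannot show which of the two matters.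

From the compounds shown here alone, it remains open how a chlorine, a methoxy group or a nitrile would behave in place of the trifluoromethyl on the 2-(trifluoromethyl)phenyl of compound 3. The same change at one fixed place on both cores is also left open.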